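Cyano for Chloro on the Thiazole of Compound 3

The compounds below may be only part of what the source reports. "The series", "measured", "known", "first", "only" and "open" are said of these compounds alone.

Measured compounds:
compound 1, `N#Cc1cnc(NC(=O)N2CCN(c3ccc(Cl)c(Cl)c3)CC2)s1`: 1.95 h
compound 2, `Cc1ccc(N2CCN(C(=O)Nc3ncc(Cl)s3)CC2=O)cc1Cl`: 1 h
compound 3, `O=C(Nc1ncc(Cl)s1)N1CCN(c2cnc(Cl)c(Cl)c2)CC1`: 0.917 h

Three ureas have been run in an ADME assay on microsomes from liver (Mus musculus) for metabolic stability, read by LC-MS, with a stated time of 60 min, tested at 1 uM; on this read-out higher numbers stand for a longer-lived compound and lower numbers for a shorter-lived compound. Compound 1 gives 1.95 h, compound 2 gives 1 h and compound 3 gives 0.917 h. Compound 3 therefore stands lowest of the three numbers; its gap to compound 2 is within the usual scatter, so the two cannot be ordered, while its gap to compound 1 lies beyond it.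

The next compound, compound 4, `N#Cc1cnc(NC(=O)N2CCN(c3cnc(Cl)c(Cl)c3)CC2)s1`, keeps the core of compound 3 and differs in one place: cyano in place of chloro on an aromatic carbon. Compound 1 also carries a cyano group on its five-membered ring and shows the higher value in this assay, but compound 1 and compound 3 differ in more than one place, so no single step can be read from them. Among the measured compounds shown here, no step between measured compounds is available for this change.

On that basis only a modest rise in this assay is expected for compound 4, and the step of a 1.4-fold higher number from compound 3 to compound 4 (0.15 log units; within the scatter) is estimated to reach about the edge of the scatter. Compound 4 is expected to give 1.3 h, with a range from 0.65 h to 2.6 h.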

Compound 4, half-life in the Mus musculus assay: 1.33 h
Compound 4: middle estimate off by 1.0-fold (0.01 log units), on the low side; low and high end bracket the measured number.
By their numbers in the Mus musculus assay, from the lowest: compounds 3, 2, 4 and 1 (each within the scatter of the next, the first and the last beyond it).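

On the change from 5-chloro-1,3-thiazol-2-yl to 5-cyano-1,3-thiazol-2-yl, the Mus musculus assay now gives a reading at this position in one place only, a 1.5-fold higher number from compound 3 to compound 4 (0.16 log units; within the scatter), and the change on the ring nitrogen gets its own reading, a 1.5-fold lower number from compound 1 to compound 4 (0.17 log units; within the scatter), so each of these two single changes stays within the scatter. In a physicochemical assay for solubility, read by nephelometry, at pH 6.5 (a lower number here means a less soluble compound, a higher number a more soluble compound), compound 3 gives < 1600 nM, which is a limit of the assay and not a number. In the physicochemical assay compound 4 gives < 1600 nM, which is likewise a limit.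

The step from chloro to cyano in the physicochemical assay therefore cannot be read, because both compounds stand at the same limit: the limit of < 1600 nM in the physicochemical assay, at which 2 of the 2 values shown sit.

The compounds shown leave open how a methyl group or a carboxamide on the same aromatic carbon, next to the ring sulfur, would stand in the Mus musculus assay, and whether cyano in place of chloro would give a step of similar size on the core of compound 2.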